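This account rests on a few compounds, and the source may have more. Where it says the series, first, only, none or still open, it means among the compounds named here.

Two stilbenes of the shared core are in hand: compound 1 `COc1ccc(/C=C/c2ccc(F)cc2)cc1` and compound 2 `Cc1ccc(/C=C/c2ccc(F)c(F)c2)cc1`. In an assay on HepG2 cells for activation of nuclear factor erythroid 2-related factor 2 (Homo sapiens), read by a luciferase reporter, with a stated time of 5 h (a higher number here means that more compound is needed for the effect, a lower number that less compound is needed), compound 1 gives 4200 nM, and compound 2 gives 2600 nM; the two numbers lie within the scatter of each other, so neither compound is separated from the other. Compound 3 `COc1ccc(/C=C/c2ccc(F)c(F)c2)cc1` is not yet measured; it differs from compound 2 by methoxy in place of methyl on an aromatic carbon. Among the measured compounds shown here, no measured pair isolates this exchange, and the two values in hand give no ground for a shift beyond the scatter in either direction. For compound 3 the expected value in this assay is 3500 nM, within 1500 nM to 8000 nM, an expected step of a 1.3-fold higher number from compound 2 to compound 3 (0.13 log units; within the scatter).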

Compound 3, half-maximal effective concentration: > 15000 nM
Compound 3 gave a limit, no number (the forecaster's own chance of this, stated with the estimate: 5%); at least 4.2-fold (0.63 log units) between middle value and limit.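

Compound 3 stands at a limit and not a number: the limit of > 15000 nM in this assay, at which 1 of the 3 values shown sits. Methoxy in place of methyl on the aromatic carbon para to a large group is not a neutral exchange here, with an at least 5.7-fold higher number from compound 2 to compound 3 (0.76 log units; beyond the scatter), something the two earlier values could not isolate. Fluoro in place of hydrogen moves the number the same way, with an at least 3.5-fold higher number from compound 1 to compound 3 (0.55 log units; beyond the scatter), so both single exchanges lie beyond the scatter.

From the compounds shown here alone, whether an ethyl chain or an amine on that carbon keeps a measurable value stays open. Going by these compounds, the true number behind the limit also stays open.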